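Bromo removal on the aryl ring of the chalcone series

A few compounds are considered here, and "the series" means these few. Any claim that something is new, unique, unknown or untested is made for them only; others in the source may bear on it.

Going by the values given here, compound 2 `O=C(COc1ccc(C(=O)/C=C/c2cccc(Br)c2)cc1)N[C@H]1CCOC1=O` is the only member with a numerical result in a functional assay on MGC-803 cells (Homo sapiens) for antiproliferative activity, read by MTT assay, with a stated time of 72 h (a higher number here means a weaker inhibitor, a lower number a stronger inhibitor), where compound 2 gives 11900 nM. Compound 1 `O=C(COc1ccc(C(=O)/C=C/c2ccc(F)cc2)cc1)N[C@H]1CCOC1=O` reaches only the limit > 64000 nM in this assay. Among the compounds with values here, the single measured step, an at least 5.3-fold lower number from compound 1 to compound 2 (0.73 log units; beyond the scatter), changes both the halogen and its place, so it bears only loosely on the present change. Compound 3 `O=C(COc1ccc(C(=O)/C=C/c2ccccc2)cc1)N[C@H]1CCOC1=O` differs from compound 2 by hydrogen in place of bromo on an aromatic carbon. Because compound 1 sits at the limit of > 64000 nM in this assay, at which 1 of the 2 values shown sits, without any bromo group, a weakening is expected for compound 3, with the expected step of a 2.7-fold higher number from compound 2 to compound 3 (0.43 log units; beyond the scatter). Compound 3 is thus estimated at 32000 nM, between 11000 nM and 90000 nM.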

Compound 3, half-maximal inhibitory concentration: > 64000 nM
Compound 3 gave a limit, no number; the forecaster's own chance of this, stated with the estimate: 35%; middle value at least 2.0-fold (0.30 log units) from the limit.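

Taken alone, with the fluoro of compound 1 out of the comparison, loss of the bromo from the 3-bromophenyl group costs measurable activity in this assay: an at least 5.3-fold higher number from compound 2 to compound 3 (0.73 log units; beyond the scatter). Compound 3 gives only a limit, so the full size of this step is not given, and the unsubstituted phenyl falls at the same reading as compound 1: the limit of > 64000 nM in this assay, at which 2 of the 3 values shown sit. The step between compound 1 and compound 3 cannot be read, as both values are limits.

As far as these compounds go, whether the gain belongs to the bromo itself or to any group on that aromatic carbon stays open. A chloro, methoxy or trifluoromethyl group there would help separate the two.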